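Notes on the oxime series: compound 3 to compound 4

The compounds below may be only part of what the source reports. "The series", "measured", "known", "first", "only" and "open" are said of these compounds alone.

Measured so far in a functional assay (blood) for inhibition, with Homo sapiens as the target; on this read-out lower numbers stand for stronger inhibition and higher numbers for weaker inhibition:
compound 1, `COC1(c2cc(F)cc(Sc3ccc4c(c3)CC/C4=N\OCC#N)c2)CCOCC1`, gives 30 nM
compound 2, `C/C(=N\O)c1cccc(Sc2cc(F)cc(C3CCOCC3)c2)c1`, gives 2910 nM
compound 3, `C/C(=N\OC(=O)C(C)(C)C)c1ccc(Sc2cc(F)cc(C3CCOCC3)c2)cc1`, gives 40 nM

Compound 3 stands second highest of the three numbers. Its nearest neighbour is compound 1, whose number is lower by a margin within the scatter, so no order between the two can be read. Compound 2 lies furthest away, beyond the scatter, with the highest number of the set. For the measured compounds named here, compound 1 and compound 2 each differ from compound 3 in more than one place, so only their values are set side by side here; no single step between measured compounds is available.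

Compound 4, `C/C(=N\OC(C)C)c1ccc(Sc2cc(F)cc(C3CCOCC3)c2)cc1`, is not yet measured. It differs from compound 3 in one place:

isopropyl in place of (tert-butyl)carbonyl on an oxygen

Going by the values given here, no measured pair carries this change, so its size is open. Since compound 3 gives 40 nM and compound 1 gives 30 nM, each with a group on the oxygen, the change is expected to cost little, a modest weakening that may not exceed the scatter: a 2.0-fold higher number from compound 3 to compound 4 (0.30 log units; within the scatter). Compound 4 is therefore estimated at 80 nM, with a range from 25 nM to 300 nM in this assay.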

Compound 4, half-maximal inhibitory concentration: 920 nM
Compound 4: the middle estimate sits 12-fold (1.06 log units) below what was measured; measured number outside the range, above it.
By their numbers in this assay, from the lowest: compounds 1 and 3 (each within the scatter of the next); then compound 4; then compound 2.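

In this assay, the group on the oxygen whose other neighbour is the double-bonded nitrogen proves to be a sensitive point: isopropyl in place of (tert-butyl)carbonyl gives a 23-fold higher number from compound 3 to compound 4 (1.36 log units; beyond the scatter). For the compounds shown here, this is the first single-place step, and it shows that having some group on this oxygen is not enough to keep the number near that of compound 3; the identity of the group counts. The step removes a carbonyl and replaces a larger group with a smaller one, so several things change at once, and nothing available bears on which of them accounts for the size of the step.

The compounds shown leave open whether a tert-butyl group bound directly to this oxygen, with no carbonyl, or an acetyl group, with the carbonyl but a smaller chain, would read closer to compound 3 or to compound 4. Also open, as far as these compounds go, is how a longer chain such as n-butyl, or a chain ending in a carboxylic acid or an amine, would read at this oxygen.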